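The source may hold more compounds than are shown below. What is called first, only, known or untested is meant among the compounds shown, and "the series" means these compounds.

Measured in a functional assay on HT-29 cells (Homo sapiens) for inhibition, read by sulforhodamine B assay, with a stated time of 48 h; on this read-out higher numbers stand for weaker inhibition of growth and lower numbers for stronger inhibition of growth:
compound 1 `O=C1C=CCC(/C=C/c2ccc(C(F)(F)F)cc2)O1` gives 36.2 uM;
compound 2 `COc1ccc(/C=C/C2CC=CC(=O)O2)cc1` gives 33.7 uM;
compound 3 `COc1ccc(/C=C/C2CC=CC(=O)O2)c(OC)c1` gives 6.6 uM.

Compound 2 stands second highest of the three numbers in this assay. Its nearest neighbour is compound 1, with a 1.1-fold lower number from compound 1 to compound 2 (0.03 log units; within the scatter); its furthest is compound 3, with a 5.1-fold lower number from compound 2 to compound 3 (0.71 log units; beyond the scatter).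

Compound 4 `COc1ccc(/C=C/C2CC=CC(=O)O2)cc1OC` has not yet been measured. The change from compound 2 to compound 4 is as follows: methoxy in place of hydrogen on an aromatic carbon.

One measured step is of the same kind, methoxy in place of hydrogen on an aromatic carbon: a 5.1-fold lower number from compound 2 to compound 3 (0.71 log units; beyond the scatter). There the methoxy entered at a different place on the same ring. The step of a 1.1-fold lower number from compound 1 to compound 2 (0.03 log units; within the scatter) exchanges one group for another at one place and does not bear on an added methoxy.

On this basis a lower number in this assay is expected for compound 4, of a size comparable to the step from compound 2 to compound 3. Among the measured compounds shown here, only one step of this kind is known; the range is set wide. The expected step is a 3.1-fold lower number from compound 2 to compound 4 (0.49 log units; beyond the scatter). Compound 4 is estimated at 11 uM, within 4 uM to 34 uM.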

Compound 4, concentration for growth inhibition (reported as GI): 17.2 uM
The estimate for compound 4 lay 1.6-fold (0.19 log units) below the measured number, and the stated range covers the measured number.
By their numbers in this assay, from the lowest: compound 3; then compounds 4, 2 and 1 (each within the scatter of the next, the first and the last beyond it).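

In this assay a methoxy placed ortho to a methoxy group and meta to a group of 9 heavy atoms gives a 2.0-fold lower number from compound 2 to compound 4 (0.29 log units; within the scatter) and so no change that can be read at this place. The same replacement of hydrogen at a different place on the same ring gave a 5.1-fold lower number from compound 2 to compound 3 (0.71 log units; beyond the scatter) and so a step that can be read, which shows that an added methoxy does not give a readable step at every place on this ring. No measurement shown here offers an explanation for this difference between the two places.

The compounds shown leave open whether a group other than methoxy at this place, such as an amine, a carboxylic acid or a longer chain like butoxy, would give a step beyond the scatter. They also leave open whether the two steps would keep this relationship on cells other than HT-29.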